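Sulfonyl aryl swap: from compound 3 to compound 4

A few compounds are considered here, and "the series" means these few. Any claim that something is new, unique, unknown or untested is made for them only; others in the source may bear on it.

Within the data shown here, compound 3 `N#Cc1cccc(S(=O)(=O)c2cnc3cc(F)ccc3c2-c2cccc(F)c2)c1` gives 0.78 mL/min in an ADME assay on microsomes from liver (Homo sapiens) for metabolic stability, tested at 2.5 uM (a lower number here means slower removal, a higher number faster removal of the compound), the lowest of the three numbers measured so far. Compound 2 `COc1ccc(-c2c(S(=O)(=O)c3cccc(C#N)c3)cnc3cc(F)ccc23)cc1` gives 0.92 mL/min, and the step of a 1.2-fold lower number from compound 2 to compound 3 (0.07 log units; within the scatter) lies within the scatter. Compound 1 `COc1cccc(-c2c(S(=O)(=O)c3cccc(C#N)c3)cnc3cc(F)ccc23)c1` gives 1.83 mL/min, and the step of a 2.3-fold lower number from compound 1 to compound 3 (0.37 log units; beyond the scatter) is modest, while a 2.0-fold lower number from compound 1 to compound 2 (0.30 log units; within the scatter) stays within the scatter.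

Compound 4 `O=S(=O)(c1ccc(F)cc1)c1cnc2cc(F)ccc2c1-c1cccc(F)c1` differs from compound 3 by 4-fluorophenyl in place of 3-cyanophenyl on a sulfonyl sulfur. Every measured step changes the aryl on the aromatic carbon and leaves the aryl on the sulfonyl sulfur untouched, so none bears directly on this change, and the steps seen run from within the scatter to modest. With no direct guide, the step of a 1.2-fold higher number from compound 3 to compound 4 (0.09 log units; within the scatter) is expected to stay within the scatter. Compound 4 is therefore estimated at 0.95 mL/min, with a range from 0.45 mL/min to 2 mL/min.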

Compound 4, intrinsic clearance in a liver preparation (reported as CLH), per the amount of preparation that the assay uses: 0.95 mL/min
For compound 4 middle estimate and measured number coincide at the digits printed; low and high end bracket the measured number.
By their numbers in this assay, from the lowest: compounds 3, 2, 4 and 1 (each within the scatter of the next, the first and the last beyond it).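

Among these compounds, the aryl on the sulfonyl sulfur now changes for the first time, and in this assay the step (a 1.2-fold higher number from compound 3 to compound 4 (0.09 log units; within the scatter)) stays within the scatter. In this single pair, 4-fluorophenyl in place of 3-cyanophenyl leaves the number unresolved from that of compound 3, so the nitrile is not needed to keep it there. No measurement at hand accounts for this.

Open, from the compounds shown here alone, is whether an amine or a carboxylic acid on the sulfonyl aryl would move the number beyond the scatter. Also open, going by these compounds, is whether the same swap behaves alike with the methoxyphenyl groups of compound 1 and compound 2.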